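The compounds below may be only part of what the source reports. "The series", "measured", "known", "first", "only" and "open" are said of these compounds alone.

Measured in an ADME assay on BJ cells (Homo sapiens), read by MTT assay, with a stated time of 72 h; a higher number here means a weaker inhibitor, a lower number a stronger inhibitor:
compound 1 `C#Cc1cn([C@@H]2O[C@H](CO)[C@@H](O)[C@H]2O)c2ncnc(NC)c12`: 86000 nM
compound 2 `Cc1ncnc2c1c(-c1cccs1)cn2[C@@H]1O[C@H](CO)[C@@H](O)[C@H]1O`: > 100000 nM (a limit)

For compound 2 the reading is a limit and not a number: > 100000 nM. Compound 3 `C#Cc1cn([C@@H]2O[C@H](CO)[C@@H](O)[C@H]2O)c2ncnc(C)c12` carries ethynyl in place of thiophen-2-yl on an aromatic carbon of a five-membered aromatic ring with 1 nitrogen (ethynyl in place of thiophen-2-yl on an aromatic carbon). Among the compounds with values here, no measured step covers this change. Compound 1, which also carries ethynyl, gives 86000 nM, so a moderate move toward stronger inhibition is expected in this assay. The expected step is an at least 3.3-fold lower number from compound 2 to compound 3 (0.52 log units; beyond the scatter). For compound 3 the estimated value is 30000 nM, with an expected range of 3000 nM to 100000 nM.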

Compound 3, half-maximal inhibitory concentration: 50 nM
Compound 3: the middle estimate sits 600-fold (2.78 log units) above what was measured; measured number outside the range, below it.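

In this assay, ethynyl in place of thiophen-2-yl on an aromatic carbon gives an at least 2000-fold lower number from compound 2 to compound 3 (3.30 log units; beyond the scatter), a step with an open end. Compound 2 reads as a limit and not a number: the limit of > 100000 nM in this assay, at which 1 of the 3 values shown sits. Methyl in place of methylamino gives a 1700-fold lower number from compound 1 to compound 3 (3.24 log units; beyond the scatter), so ethynyl alone does not bring the low number, since compound 1 carries ethynyl and compound 2 carries methyl, and only compound 3 combines the two.

From the compounds shown here alone, whether a longer alkynyl chain or a nitrile on that aromatic carbon keeps the number low remains open. So does the effect of ethyl or a primary amine in place of methyl.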